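A Larger Nitrogen Substituent on a Phenoxyacetamide Scaffold

The source may report more compounds than this note shows. Statements on the series, on what has been measured and on what is new or still open speak of the compounds shown alone.

Three amides that share a phenoxyacetamide backbone have been tested in an assay on HEK293 cells for agonist activity at transient receptor potential cation channel subfamily M member 8 (Homo sapiens), read by fluorescence and calcium flux, with a stated time of 15 min; on this read-out lower numbers stand for an effect already at smaller amounts and higher numbers for an effect only at larger amounts of compound. Compound 1 `CCN(Cc1ccc(C)s1)C(=O)COc1ccc(C)cc1` gives 178 nM. Compound 3 `CCN(Cc1cccs1)C(=O)COc1ccc2c(c1)CCC2`, in which the aromatic ring on the ether side is fused into a second ring, gives 0.8 nM. Compound 2 `Cc1ccc(OCC(=O)N(C)Cc2cccs2)cc1` gives 400 nM, the highest number of the three: the gap to compound 1 and the far larger gap to compound 3 both lie beyond the usual scatter, so compound 2 is the least potent of the measured set.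

Compound 4 `CCC(C)N(Cc1cccs1)C(=O)COc1ccc(C)cc1` is not yet measured. It differs from compound 2 in one place: sec-butyl in place of methyl on an amide-type nitrogen. Within the data shown here, nothing in the measured set changes the nitrogen substituent alone, so there is no directly comparable step; compound 1 combines a longer nitrogen chain with a second change elsewhere, and its number is lower than that of compound 2. On that thin basis a modest shift toward a lower number in this assay seems more likely than none. Compound 4 is expected to give about 110 nM, with a plausible range from 25 nM to 450 nM. The expected step from compound 2 to compound 4 is therefore a 3.6-fold lower number from compound 2 to compound 4 (0.56 log units; beyond the scatter), though a result within the scatter of compound 2 would not be surprising.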

Compound 4, half-maximal effective concentration: 2000 nM
The estimate for compound 4 lay 18-fold (1.26 log units) below the measured number, outside the stated range (above it).
By their numbers in this assay, from the lowest: compound 3; then compound 1; then compound 2; then compound 4.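

This is the only step shown that changes the nitrogen substituent alone: in this assay, sec-butyl in place of methyl on the amide-type nitrogen gives a 5.0-fold higher number from compound 2 to compound 4 (0.70 log units; beyond the scatter). Among these compounds, on this scaffold, then, this nitrogen does not simply reward a larger group, since the bigger sec-butyl raises the number and so lowers potency, though only this one pair supports that reading. No measurement is available to explain the change, so its cause remains unknown.

Going by these compounds, it remains open whether the rise follows from the extra carbons or from the branching of the chain, a question that a straight butyl chain on the same nitrogen could help settle. A cyclopropyl group there would test a compact ring in the same place.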